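Removing the Chloro Group from an Aryl Amide Series

The compounds below may be only part of what the source reports. "The series", "measured", "known", "first", "only" and "open" are said of these compounds alone.

Compound 1 `O=C(Nc1ccc(Cl)cc1)c1cncc(N2CC3CC(C2)N3)c1`: 123 nM
Compound 2 `COc1ccc(NC(=O)c2cncc(N3CC4CC(C3)N4)c2)cc1OC`: 516 nM

Of the compounds shown here, two sharing the same core have been measured in an assay on cells for displacement of a labelled ligand from Neuronal acetylcholine receptor; alpha3/beta4 (Homo sapiens); on this read-out lower numbers stand for stronger inhibition and higher numbers for weaker inhibition. Compound 1 gives 123 nM and holds the lowest number of the two. Compound 2 gives 516 nM, a higher number, and the gap between the two lies beyond the scatter. Among the measured compounds shown here, no pair of measured compounds differs in only one place, so the effect of a single change cannot be read from these two numbers alone.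

Compound 3 `O=C(Nc1ccccc1)c1cncc(N2CC3CC(C2)N3)c1` differs from compound 1 in one place: hydrogen in place of chloro on an aromatic carbon. The expectation for compound 3 therefore rests on compound 1 and on the weaker number of compound 2. Since the stronger of the two measured compounds carries the chloro group, its removal is expected to move the number in this assay upward, by a step that may just reach beyond the scatter. Compound 3 is estimated at 300 nM, with a range from 120 nM to 800 nM. This corresponds to an expected step of a 2.4-fold higher number from compound 1 to compound 3 (0.39 log units; beyond the scatter).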

Compound 3, inhibition constant: 192 nM
Estimate against measurement, compound 3: 1.6-fold (0.19 log units) above, and the stated range covers the measured number.
By their numbers in this assay, from the lowest: compounds 1 and 3 (each within the scatter of the next); then compound 2.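

Among the compounds shown here, replacing chloro with hydrogen on the aromatic carbon, the 4-chlorophenyl to phenyl change, gives a 1.6-fold higher number from compound 1 to compound 3 (0.19 log units; within the scatter) in this assay, and this is the first single change that can be read. At this place, para to a large group, the chloro group is therefore not required for a number in this range, and the compounds with chloro and with hydrogen cannot be told apart on this read-out. No measurement at hand bears on why this single change leaves the two compounds within the scatter of each other.

This one step does not show whether any other group on the same aromatic carbon, such as a nitrile, a trifluoromethyl or an amine, would stay within the scatter of compound 1 and compound 3 or move beyond it. For the compounds shown here, the separate contribution of the methoxy groups of compound 2 also remains open, as no step in a single place connects compound 2 with compound 1 or compound 3.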